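This account rests on a few compounds, and the source may have more. Where it says the series, first, only, none or still open, it means among the compounds named here.

Working notes on the series. The core shared by compound 1 `Nc1nc(NC2CC2)c2ncn(/C=C3/CC3(CO)CO)c2n1`, compound 2 `Nc1nc(OCC(F)(F)F)c2ncn(/C=C3/CC3(CO)CO)c2n1` and compound 3 `CCOc1nc(N)nc2c1ncn2/C=C1/CC1(CO)CO` was tested in an ADME assay on CCRF-HSB-2 cells (Homo sapiens) for cytotoxicity, with a stated time of 7 days; on this read-out higher numbers stand for lower toxicity in this test and lower numbers for higher toxicity in this test. In this assay compound 1 gives > 20000 nM, which is a limit of the assay. Compound 2 gives > 20000 nM, likewise a limit. Compound 3 gives > 20000 nM, again a limit. The steps a step that the two limits leave unreadable from compound 1 to compound 2, a step that the two limits leave unreadable from compound 1 to compound 3 and a step that the two limits leave unreadable from compound 2 to compound 3 therefore cannot be sized, all three values sitting at the limit of > 20000 nM in this assay, at which 3 of the 3 values shown sit. Compound 4 `CNc1nc(N)nc2c1ncn2/C=C1/CC1(CO)CO` is not yet measured; its change from compound 2 is methylamino in place of 2,2,2-trifluoroethoxy on an aromatic carbon. With every measured value at the limit of > 20000 nM in this assay, at which 3 of the 3 values shown sit, no step beyond the scatter is expected for compound 4. Compound 4 is expected at 20000 nM, between 10000 nM and 50000 nM. The expected step of a number no higher from compound 2 to compound 4 (the limit leaves the size open) is thus none beyond the scatter.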

Compound 4, half-maximal cytotoxic concentration: > 20000 nM
Compound 4: no number, only a limit (the forecaster's own chance of this, stated with the estimate: 85%); the middle value lies on the limit itself.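

Compound 4 adds no readable step to compound 1, compound 2 or compound 3 in this assay, and all of these steps stay unreadable: the limit of > 20000 nM in this assay, at which 4 of the 4 values shown sit.

The compounds shown leave open whether these groups on the aromatic carbon differ at all in cytotoxicity, since none of them gives a number.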